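A few compounds are considered here, and "the series" means these few. Any claim that something is new, unique, unknown or untested is made for them only; others in the source may bear on it.

Measured in a functional assay on the whole organism (strain Swiss albino) with Mus musculus as the target, with a stated time of 0.5 h (a lower number here means that less compound is needed, a higher number that more compound is needed for the effect), so far:
- compound 1 `COc1cc2c(cc1OC)C(=O)C(CC1CCN(C(=S)Nc3ccccc3C)CC1)C2`: 300 mg/kg
- compound 2 `COc1cc2c(cc1OC)C(=O)C(CC1CCN(C(=S)Nc3cccc(C)c3)CC1)C2`: "not determined" (no result reported)
- compound 3 `COc1cc2c(cc1OC)C(=O)C(CC1CCN(C(=S)Nc3ccc(C)cc3)CC1)C2`: 100 mg/kg

Compound 3 holds the lowest of the two numbers in this assay. Its nearest neighbour is compound 1, which needs more compound: a 3.0-fold lower number from compound 1 to compound 3 (0.48 log units; beyond the scatter). Compound 2 carries no number in this assay, so it adds nothing to the picture.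

Compound 4 `COc1cc2c(cc1OC)C(=O)C(CC1CCN(C(=S)Nc3ccc([N+](=O)[O-])cc3)CC1)C2` is not yet measured. Its difference from compound 3: nitro in place of methyl on an aromatic carbon. Going by the values given here, the one measured step, a 3.0-fold lower number from compound 1 to compound 3 (0.48 log units; beyond the scatter), exchanges 2-methylphenyl for 4-methylphenyl and keeps the methyl group itself; it says nothing about replacing methyl by nitro on the aromatic carbon. Among the compounds with values here, no measured pair in this set bears directly on the change from compound 3 to compound 4. Within the data shown here, with no step to lean on, the working assumption is that the change stays within the usual scatter of this assay, with a wide margin in either direction.

Compound 4 is therefore expected to give about 100 mg/kg in this assay, with a range of 30 mg/kg to 300 mg/kg. The expected step of no change at the digits printed from compound 3 to compound 4 (within the scatter) is set at no change beyond the scatter.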

Compound 4, minimum effective dose: 100 mg/kg
Compound 4: the middle estimate sits on the measured number at the digits printed; measured number inside the range.
By their numbers in this assay, from the lowest: compounds 3 and 4 (each within the scatter of the next); then compound 1.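

Going by these compounds alone, until now, the only readable change in this assay moved a methyl group around the phenyl ring, leaving open whether the group at the place para to a large group could be exchanged at all. Nitro in place of methyl at that aromatic carbon gives no change at the digits printed from compound 3 to compound 4 (within the scatter), even though it brings more heavy atoms and two hydrogen-bond acceptors where methyl has none, so in this series the read-out tolerates this exchange. Compound 4 also repeats the earlier gap to the 2-methylphenyl compound, with a 3.0-fold lower number from compound 1 to compound 4 (0.48 log units; beyond the scatter), so the 4-methylphenyl and 4-nitrophenyl compounds share the same standing against compound 1, though no available evidence bears on what lies behind this result.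

The compounds shown leave open whether an amine, a carboxylic acid or a methoxy group at this same place would also hold the number seen for compound 3 and compound 4. They also leave open how nitro would read at the place of the methyl group in compound 1, and compound 2 gives no number for comparison.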